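The compounds below may be only part of what the source reports. "The series", "measured", "known", "first", "only" and "open" are said of these compounds alone.

Compound 1 `O=C(Nc1cc(-c2ccccc2)nn1-c1ccccc1)c1ccc([N+](=O)[O-])cc1` is the starting point. For the measured compounds named here, in an assay on HEK293 cells for displacement of a labelled ligand from metabotropic glutamate receptor 5 (Rattus norvegicus) (on this read-out higher numbers stand for weaker inhibition and lower numbers for stronger inhibition), compound 1 gives 250 nM, the higher of the two numbers measured so far. Compound 3 `O=C(Nc1cc(-c2ccccc2)nn1-c1ccccc1Br)c1ccc([N+](=O)[O-])cc1` gives 120 nM in this assay, and the step is a 2.1-fold lower number from compound 1 to compound 3 (0.32 log units; beyond the scatter). Compound 2 `O=C(Nc1cc(-c2ccccc2Cl)nn1-c1ccccc1)c1ccccc1` sits at the limit of > 10000 nM in this assay, at which 1 of the 3 values shown sits; its result of > 10000 nM is a limit of the assay, not a number.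

Compound 4 `O=C(Nc1cc(-c2ccccc2)nn1-c1ccccc1)C1CCCC1` differs from compound 1 by cyclopentyl in place of 4-nitrophenyl on a carbonyl carbon. Going by the values given here, the only measured step concerns a different part of the molecule, an aromatic carbon, and so gives no direct guide to a change at the carbonyl carbon; the size and direction of the step are therefore uncertain. Compound 4 is expected to give about 1000 nM in this assay, within a range from 200 nM to 6000 nM, which would mean a 4.0-fold higher number from compound 1 to compound 4 (0.60 log units; beyond the scatter).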

Compound 4, inhibition constant: 11600 nM
For compound 4 the middle estimate is 12-fold (1.06 log units) below the measured one; measured number above the stated range.
By their numbers in this assay, from the lowest: compound 3; then compound 1; then compound 4.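

In this assay, the group on the carbonyl carbon has a far larger effect than the bromo on an aromatic carbon: cyclopentyl in place of 4-nitrophenyl gives a 46-fold higher number from compound 1 to compound 4 (1.67 log units; beyond the scatter), against a 2.1-fold lower number from compound 1 to compound 3 (0.32 log units; beyond the scatter) for the bromo change. This single swap removes both the aromatic ring and the nitro group, so the result cannot separate the two.

Still open, going by these compounds, is whether a 4-methoxyphenyl or a 4-aminophenyl on the carbonyl carbon would keep the binding seen with 4-nitrophenyl. No measurement shown gives a reason for this large step.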